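Nitro for trifluoromethyl on the pendant aryl of compound 1

This account rests on a few compounds, and the source may have more. Where it says the series, first, only, none or still open, it means among the compounds named here.

Compound 1 `CCOC(=O)[C@@H]1/C(=C/C(=O)c2ccccc2)N=C(C)/C(=C(/O)OCC)[C@H]1c1ccccc1C(F)(F)F` carries a trifluoromethyl group on its pendant aryl ring and an unsubstituted phenyl on the carbonyl. In an assay on brain for binding affinity to Voltage-gated L-type calcium channel (Rattus norvegicus) (a lower number here means a stronger inhibitor, a higher number a weaker inhibitor), compound 1 gives 297 nM, the highest number of the three measured. Compound 2 `CCOC(=O)[C@@H]1/C(=C/C(=O)c2ccncc2)N=C(C)/C(=C(/O)OCC)[C@H]1c1ccccc1C(F)(F)F` gives 25.5 nM in this assay, and compound 3 `CCOC(=O)[C@@H]1/C(=C/C(=O)c2ccc(N(C)C)cc2)N=C(C)/C(=C(/O)OCC)[C@H]1c1ccccc1C(F)(F)F` gives 31.7 nM. The two measured steps both act on the aryl attached to the carbonyl: a 12-fold lower number from compound 1 to compound 2 (1.07 log units; beyond the scatter) and a 9.4-fold lower number from compound 1 to compound 3 (0.97 log units; beyond the scatter), while a 1.2-fold higher number from compound 2 to compound 3 (0.09 log units; within the scatter) lies within the scatter.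

Compound 4 `CCOC(=O)[C@@H]1/C(=C/C(=O)c2ccccc2)N=C(C)/C(=C(/O)OCC)[C@H]1c1ccccc1[N+](=O)[O-]` differs from compound 1 at a different place: nitro in place of trifluoromethyl on an aromatic carbon, on an aromatic carbon of a six-membered aromatic ring of carbon only, ortho to a large group. For the measured compounds named here, no measured step touches this ring, so the measured steps give no direct guide to its size or direction. With the carbonyl-side phenyl kept as in compound 1, the number for compound 4 in this assay is expected to stay near that of compound 1; the estimated step is a 1.0-fold higher number from compound 1 to compound 4 (0.00 log units; within the scatter). The estimate for compound 4 is 300 nM, with a range from 90 nM to 1000 nM.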

Compound 4, half-maximal inhibitory concentration: 31.1 nM
The estimate for compound 4 lay 9.6-fold (0.98 log units) above the measured number, outside the stated range (below it).
By their numbers in this assay, from the lowest: compounds 2, 4 and 3 (each within the scatter of the next); then compound 1.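

In this assay, the pendant aryl ring is a second place where the number moves: with the carbonyl-side phenyl kept, nitro in place of trifluoromethyl gives a 9.5-fold lower number from compound 1 to compound 4 (0.98 log units; beyond the scatter) on an aromatic carbon ortho to a large group. For the compounds shown here, the earlier steps all act on the aryl attached to the carbonyl, so this is the first measured sign that the number also depends on the group held on the pendant ring. Nothing in hand bears on the cause of this step.

As far as these compounds go, whether the same step holds with pyridin-4-yl or 4-(dimethylamino)phenyl on the carbonyl stays open. Also open, from the compounds shown here alone, is how a nitrile, a chlorine atom or an amine at this place would read in this assay against compound 1 and compound 4.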